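This account rests on a few compounds, and the source may have more. Where it says the series, first, only, none or still open, it means among the compounds named here.

Measured so far:
Compound 1, `N#Cc1c(-c2ccccc2)nc(SCC(=O)Nn2c(COc3ccc(Cl)cc3Cl)nc3ccccc3c2=O)n(Cc2ccccc2)c1=O`, in a functional assay on the whole organism (strain albino) for inhibition, with Rattus norvegicus as the target, read by paw edema, with stated times of 1 h and 2 h, at a dose of 100 mg/kg by the oral route (on this read-out higher numbers stand for more inhibition at the one dose given (going by the name of the read-out) and lower numbers for less inhibition), gives 79%.
Compound 2, `N#Cc1c(-c2ccc(Cl)cc2)nc(SCC(=O)Nn2c(COc3ccc(Cl)cc3Cl)nc3ccccc3c2=O)n(Cc2ccccc2)c1=O`, in this assay gives 77.2%.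
Compound 3, `Cn1c(SCC(=O)Nn2c(COc3ccc(Cl)cc3Cl)nc3ccccc3c2=O)nc(-c2ccc(O)cc2)c(C#N)c1=O`, in this assay gives 86%.

Compound 3 holds the highest of the three numbers, but its distance to compound 1 and to compound 2 is within the scatter in each case, so no order among the three can be claimed. Going by the values given here, the one single-point step in the set, a number 1.8 percentage points lower from compound 1 to compound 2 (within the scatter), is also within the scatter.

Compound 4, `N#Cc1c(-c2ccc(O)cc2)nc(SCC(=O)Nn2c(COc3ccc(Cl)cc3Cl)nc3ccccc3c2=O)n(Cc2ccccc2)c1=O`, is still to be measured in this assay. It differs from compound 3 by phenyl in place of hydrogen on a saturated chain carbon bound to an aromatic nitrogen. Among the compounds with values here, none of the measured steps covers this change: the only measured step, chloro in place of hydrogen on an aromatic carbon, lies elsewhere and was within the scatter. Both compound 1 and compound 2 carry a benzyl on the same nitrogen; compound 1 shows 79% and compound 2 shows 77.2%, each again within the scatter of compound 3. No step beyond the scatter is therefore expected, a number 4 percentage points lower from compound 3 to compound 4 (within the scatter) being the estimated change. For compound 4 the expected value in this assay is 82%, with an estimated range from 70% to 92%.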

Compound 4, a percentage reported as inhibition, in the whole organism at one dose (the size of the read-out at that dose, not a potency): 56.1%
Compound 4: the middle estimate sits 25.9 percentage points above what was measured; the measured number lies below the stated range.
By their numbers in this assay, from the lowest: compound 4; then compounds 2, 1 and 3 (each within the scatter of the next).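

With hydroxy held on the aromatic ring, moving from methyl to benzyl gives a number 29.9 percentage points lower from compound 3 to compound 4 (beyond the scatter) in this assay, so phenyl in place of hydrogen on a saturated chain carbon bound to an aromatic nitrogen is a change this read-out registers. With benzyl held, the substituent on the aromatic carbon also proves not to be silent: hydroxy in place of hydrogen gives a number 22.9 percentage points lower from compound 1 to compound 4 (beyond the scatter) and hydroxy in place of chloro gives a number 21.1 percentage points lower from compound 2 to compound 4 (beyond the scatter), whereas chloro in place of hydrogen had given only a number 1.8 percentage points lower from compound 1 to compound 2 (within the scatter). The hydroxy group does not go with a low number on its own, since compound 3 carries it too and gives 86%, so the lower number appears here only where hydroxy and benzyl occur together, and nothing at hand offers an account of either step.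

As far as these compounds go, it remains open whether the step from methyl to benzyl keeps its size when the aromatic ring carries hydrogen or chloro instead of hydroxy. Also open, from the compounds shown here alone, is how a longer chain such as propyl on that nitrogen, or a methoxy or an amine in place of the hydroxy, would read in this assay.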